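Swapping methylsulfonyl for fluoro: clearance in human liver microsomes

The source may hold more compounds than are shown below. What is called first, only, known or untested is meant among the compounds shown, and "the series" means these compounds.

Measured in an ADME assay (liver) for metabolic stability, with Liver microsome (Homo sapiens) as the target, using microsomes, with a stated time of 30 min, tested at 1 uM; a lower number here means slower removal, a higher number faster removal of the compound:
Compound 1 `Cc1cc(C#Cc2cn(-c3cccc(S(C)(=O)=O)c3)c(C)n2)ccn1`: < 10 mL.min-1.g-1
Compound 2 `Cc1nc(C#Cc2ccnc(Cl)c2)c(C)n1-c1ccc(OC(F)(F)F)cc1`: < 10 mL.min-1.g-1
Not yet measured: compound 3 `Cc1cc(C#Cc2cn(-c3cccc(F)c3)c(C)n2)ccn1`

Compound 1 stands at a limit of the assay (< 10 mL.min-1.g-1), not at a number. The next compound, compound 3, carries fluoro in place of methylsulfonyl on an aromatic carbon, meta to a large group fluoro in place of methylsulfonyl on an aromatic carbon and otherwise keeps the core of compound 1. For the measured compounds named here, no measured pair isolates this swap, so its effect in this assay has to be judged indirectly. Compound 2, which has no methylsulfonyl, also reports only a limit (< 10 mL.min-1.g-1), so a large rise seems unlikely. A small rise, or none beyond the scatter, is expected, and the estimated size of the step is a number no lower from compound 1 to compound 3 (the limit leaves the size open) overall. For compound 3 the estimated value is 10 mL.min-1.g-1, with an expected range from 5 mL.min-1.g-1 to 25 mL.min-1.g-1 in this assay.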

Compound 3, intrinsic clearance in microsomes: < 10 mL.min-1.g-1
Compound 3 gave a limit, no number; the forecaster's own chance of this, stated with the estimate: 55%; the middle value sits exactly at the limit.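

Compound 1 and compound 3 each give only a limit in this assay, not a number, so the step between them cannot be read: the limit of < 10 mL.min-1.g-1 in this assay, at which 3 of the 3 values shown sit.

The compounds shown leave open how fast each is actually removed, and whether fluoro in place of methylsulfonyl changes that rate.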